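This account rests on a few compounds, and the source may have more. Where it says the series, first, only, none or still open, it means among the compounds named here.

Measured compounds:
- compound 1, `COC(=O)C1=C(C)N=C(C)/C(=C(/O)OC)C1c1cccc(OCCO[N+](=O)[O-])c1`, 970 nM
- compound 2, `COC(=O)C1=C(C)N=C(C)/C(=C(/O)OC)C1c1cccc(OCc2nonc2C)c1`, 720 nM
- compound 3, `COC(=O)C1=C(C)N=C(C)/C(=C(/O)OC)C1c1cccc(OCc2no[n+]([O-])c2C)c1`, 820 nM

All three share one core and differ only in the group on a saturated chain carbon bound to an oxygen on an aromatic ring. In an assay on Cortex for displacement of a labelled ligand from Voltage-dependent L-type calcium channel subunit alpha-1D (Rattus norvegicus) (on this read-out lower numbers stand for stronger inhibition and higher numbers for weaker inhibition), compound 3 sits between its two neighbours: the step of a 1.1-fold higher number from compound 2 to compound 3 (0.06 log units; within the scatter) and the step of a 1.2-fold lower number from compound 1 to compound 3 (0.07 log units; within the scatter) both lie within the usual scatter, so the three numbers cannot be told apart.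

Compound 4, `COC(=O)C1=C(C)N=C(C)/C(=C(/O)OC)C1c1cccc(OCc2c(C(N)=O)no[n+]2[O-])c1`, has not yet been measured. Its change from compound 3 is a group of 9 heavy atoms (3 carbon, 3 nitrogen, 3 oxygen; one five-membered aromatic ring with 3 hetero atoms) in place of a group of 7 heavy atoms (3 carbon, 2 nitrogen, 2 oxygen; one five-membered aromatic ring with 3 hetero atoms), on a saturated chain carbon bound to an oxygen on an aromatic ring. Going by the values given here, the steps that bear on this position, a 1.3-fold lower number from compound 1 to compound 2 (0.13 log units; within the scatter) and a 1.1-fold higher number from compound 2 to compound 3 (0.06 log units; within the scatter), were each within the scatter, which suggests that this assay tolerates exchanges of the group at this place. Among the compounds with values here, no measured step adds a carboxamide to the ring, so the expectation rests only on that tolerance.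

Compound 4 is therefore expected to show a step of a 1.0-fold higher number from compound 3 to compound 4 (0.02 log units; within the scatter), within the scatter. The estimate for compound 4 in this assay is 850 nM, with a range from 350 nM to 2100 nM.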

Compound 4, half-maximal inhibitory concentration: 3600 nM
Compound 4: middle estimate off by 4.2-fold (0.63 log units), on the low side; measured number above the stated range.
By their numbers in this assay, from the lowest: compounds 2, 3 and 1 (each within the scatter of the next); then compound 4.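

The tolerance seen among the first three compounds has a limit: in this assay the step of a 4.4-fold higher number from compound 3 to compound 4 (0.64 log units; beyond the scatter) lies beyond the scatter, and so do a 5.0-fold higher number from compound 2 to compound 4 (0.70 log units; beyond the scatter) and a 3.7-fold higher number from compound 1 to compound 4 (0.57 log units; beyond the scatter) when the other two groups are the starting point. Going by these compounds alone, this place accepts the nitrooxy chain and both methyl-bearing rings alike, but not every ring group, and the ring with the carboxamide is the one group here that stands apart from the rest. The entering group counts 1 hydrogen-bond donor where the leaving group counts 0, but nothing here ties the weaker result to that or to any other feature.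

Going by these compounds, whether the amide hydrogens matter, or only the size of the group, stays open. A nitrile or a carboxylic acid in place of the carboxamide on the ring could help tell these apart.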